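Side-chain stereochemistry and antiproliferative potency in a shared core

This account rests on a few compounds, and the source may have more. Where it says the series, first, only, none or still open, it means among the compounds named here.

In a functional assay on MCF7 cells (Homo sapiens) for antiproliferative activity, read by CellTiter-Glo, with a stated time of 5 days (on this read-out lower numbers stand for stronger inhibition and higher numbers for weaker inhibition), compound 1 `CC1=C(c2cccc(O)c2)C(c2ccc(OC[C@H](C)N3CCCC3)cc2)Oc2ccc(O)cc21` gives 0.2 nM and compound 2 `CC1=C(c2cccc(O)c2)C(c2ccc(OC[C@H](C)N3CC[C@H](C)C3)cc2)Oc2ccc(O)cc21` gives 0.2 nM, so no change at the digits printed from compound 1 to compound 2 (within the scatter). Among the measured compounds shown here, compound 3 `CC1=C(c2cccc(O)c2)[C@@H](c2ccc(OC[C@H](C)N3CC[C@@H](C)C3)cc2)Oc2ccc(O)cc21` gives 59 nM, the highest of the three numbers, and a 300-fold higher number from compound 2 to compound 3 (2.47 log units; beyond the scatter); the one feature marking that step is the fact that one of compounds 2 and 3 is drawn with a defined configuration and the other without, at the place where they differ. Compound 4 `CC1=C(c2cccc(O)c2)C(c2ccc(OC[C@@H](C)N3CC[C@@H](C)C3)cc2)Oc2ccc(O)cc21` differs from compound 3 in that (the two compounds have the same atoms and bonds; at least one stereo element is drawn with a configuration in one of them and without one in the other: 2 of 3 stereo elements differ; a stereocentre at a saturated ring carbon is drawn R in compound 3 and without a configuration in compound 4; a stereocentre at a saturated chain carbon is drawn S in compound 3 and R in compound 4). This change again touches only stereo elements, and one ring stereocentre returns to being drawn without a configuration, as in compound 1 and compound 2, which both carry low numbers in this assay. The expected step in this assay is a 59-fold lower number from compound 3 to compound 4 (1.77 log units; beyond the scatter), back toward lower numbers, though with real uncertainty. Compound 4 is therefore estimated at 1 nM, within a range from 0.2 nM to 10 nM.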

Compound 4, half-maximal inhibitory concentration: 0.2 nM
For compound 4 the middle estimate is 5.0-fold (0.70 log units) above the measured one, within the range that was stated.
By their numbers in this assay, from the lowest: compounds 1, 2 and 4 (each within the scatter of the next); then compound 3.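

In this assay the large step (a 300-fold lower number from compound 3 to compound 4 (2.47 log units; beyond the scatter)) shows that the ring methyl drawn R, which compounds 3 and 4 share, does not by itself bring the high number. Inverting both side-chain stereocentres leaves the number in place (no change at the digits printed from compound 2 to compound 4 (within the scatter)), and with this arrangement the methyl on the pyrrolidine also leaves it in place (no change at the digits printed from compound 1 to compound 4 (within the scatter)). The large step has one marked feature: the fact that one of compounds 3 and 4 is drawn with a defined configuration and the other without, at the place where they differ.

Going by these compounds, two stereo elements differ at once in that step, so which one carries it stays open. Also open, on these data alone, is how a piperidine ring or a dimethylamino group would read in place of the pyrrolidine.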